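The source may hold more compounds than are shown below. What is called first, only, known or untested is meant among the compounds shown, and "the series" means these compounds.

Measured compounds: compound 1 `CC[C@@H]1C(=O)N(C)c2cnc(-n3ccc4cc(C(N)=O)ccc43)nc2N1C1CCCC1`, 1850 nM; compound 2 `CC[C@@H]1C(=O)N(C)c2cnc(-n3ccc4cc(C(=O)NC5CCCC5)ccc43)nc2N1C1CCCC1`, 414 nM; compound 3 `CCC1C(=O)N(C)c2cnc(-n3ccc4cc(C(=O)NC5CCCC5)ccc43)nc2N1c1ccn(C)n1`, 31300 nM.

All three were tested in a functional assay on K562 cells (Homo sapiens) for antiproliferative activity, read by CCK-8 assay, with a stated time of 72 h; on this read-out higher numbers stand for weaker inhibition of growth and lower numbers for stronger inhibition of growth. Compound 2 and compound 1 differ by hydrogen in place of cyclopentyl on an amide-type nitrogen, and this change gave a 4.5-fold higher number from compound 2 to compound 1 (0.65 log units; beyond the scatter). Compound 3 carries the same amide as compound 2 on a different core; the difference between the two cores is not broken down here, and in this assay compound 3 gives 31300 nM, the highest number of the three. Compound 4 `CCC1C(=O)N(C)c2cnc(-n3ccc4cc(C(N)=O)ccc43)nc2N1c1ccn(C)n1` has not yet been measured. It differs from compound 3 by hydrogen in place of cyclopentyl on an amide-type nitrogen, the same change seen between compound 2 and compound 1. Compound 4 is expected to show the step of a 3.8-fold higher number from compound 3 to compound 4 (0.58 log units; beyond the scatter). This rests on the earlier step of a 4.5-fold higher number from compound 2 to compound 1 (0.65 log units; beyond the scatter). Compound 4 is therefore estimated at 120000 nM in this assay, with a likely range from 40000 nM to 350000 nM.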

Compound 4, concentration for 50% growth inhibition: 31300 nM
Compound 4: middle estimate off by 3.8-fold (0.58 log units), on the high side; the measured number lies below the stated range.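

Hydrogen in place of cyclopentyl on the amide-type nitrogen did not behave the same way on the core of compound 3 in this assay, where the step reads no change at the digits printed from compound 3 to compound 4 (within the scatter) and the cyclopentyl group made no measurable difference. The size of this step therefore did not carry from one core to the other, and the gap between the two steps is real: the same change on two cores in this assay, a 4.5-fold higher number (0.65 log units; beyond the scatter) from compound 2 to compound 1 and no change at the digits printed (within the scatter) from compound 3 to compound 4, 4.5-fold (0.65 log units) apart, beyond the scatter of two such steps. This does not show which feature of the two cores accounts for the gap, nor how the change would behave on any further core.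

The compounds shown leave open what a methyl group, a longer chain or a chain ending in an amine would do on that amide nitrogen. They also leave open whether any such group would give a step on the core of compound 3.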